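A few compounds are considered here, and "the series" means these few. Any claim that something is new, unique, unknown or untested is made for them only; others in the source may bear on it.

Three compounds open the series: compound 1 `COc1ccc(/C=C/C=C/C(=O)c2ccc(F)cc2)cc1`, compound 2 `CN(C)c1ccc(/C=C/C=C/C(=O)c2ccc(F)cc2)cc1` and compound 3 `CN(C)c1ccc(/C=C/C=C/C(=O)c2cccs2)cc1`. In an ADME assay on RAW264.7 cells (Mus musculus) for cytotoxicity, read by MTT assay (on this read-out higher numbers stand for weaker inhibition and lower numbers for stronger inhibition), compound 1 gives "not determined" (no result reported). In this assay, compound 3 also gives "not determined" (no result reported). Compound 2 gives > 100000 nM, which is a limit of the assay and not a number. Compound 2 thus stands at the limit of > 100000 nM in this assay, at which 1 of the 3 values shown sits, with no measured number to compare it with. Compound 4 `O=C(/C=C/C=C/c1ccc(O)cc1)c1ccc(F)cc1` carries hydroxy in place of dimethylamino on an aromatic carbon, para to a large group (hydroxy in place of dimethylamino on an aromatic carbon). Among the compounds with values here, no measured step in this assay guides this change. The expected step, an at least 1.4-fold lower number from compound 2 to compound 4 (0.15 log units; that floor lies within the scatter), is a small one toward stronger inhibition. For compound 4 the estimated value is 70000 nM, with an expected range of 20000 nM to 150000 nM.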

Compound 4, half-maximal inhibitory concentration: 45500 nM
Estimate against measurement, compound 4: 1.5-fold (0.19 log units) above; the range from low to high includes it.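

In this assay, the position named in the change responds to what it carries: hydroxy in place of dimethylamino on an aromatic carbon gives an at least 2.1-fold lower number from compound 2 to compound 4 (0.34 log units; beyond the scatter). This step lies beyond the usual scatter and gives the series its first measured number. Its full size remains unknown because compound 2 has a limit of the assay and not a number: the limit of > 100000 nM in this assay, at which 1 of the 4 values shown sits.

As far as these compounds go, whether a carboxylic acid or a primary amine at this place would lower the number further stays open. So does whether hydroxy would have the same effect on the core of compound 3.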